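The compounds below may be only part of what the source reports. "The series", "measured", "known", "first", "only" and "open" are said of these compounds alone.

Measured in a functional assay on T47D cells (Homo sapiens) for cytotoxicity, read by CCK-8 assay and cell counting, with a stated time of 2 days; on this read-out higher numbers stand for weaker inhibition and lower numbers for stronger inhibition:
Compound 1 `Oc1ccc(-c2cc(-c3ccccc3)nc(-c3ccccc3Cl)c2)cc1`: 5460 nM
Compound 2 `Oc1ccc(-c2cc(-c3ccc(Cl)cc3)nc(-c3cccs3)c2)cc1`: 6450 nM
Compound 3 `Oc1ccc(-c2cc(-c3ccc(Cl)cc3)nc(-c3ccsc3)c2)cc1`: 5490 nM

On the numbers shown, compound 3 falls between the other two, but all three values lie within the usual scatter of one another, so no compound is separated from another. For the measured compounds named here, the only single-point step among them, a 1.2-fold lower number from compound 2 to compound 3 (0.07 log units; within the scatter), is itself within the scatter.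

The next compound, compound 4 `Oc1ccc(-c2cc(-c3ccccc3)nc(-c3ccc(Cl)cc3)c2)cc1`, has not yet been measured in this assay. It differs from compound 3 in one place: phenyl in place of thiophen-3-yl on an aromatic carbon.

Going by the values given here, no measured step exchanges a thiophen-3-yl for a phenyl, so nothing bears directly on this change. Among the compounds with values here, compound 1, which also carries a phenyl on the shared core, gives 5460 nM in this assay, a value within the scatter of compound 3, and the one thiophene step already seen was small. Given that every number so far sits within the scatter of every other, no movement beyond the scatter is expected in this assay, in either direction.

Compound 4 is therefore expected to give about 5500 nM, with a range from 2500 nM to 12000 nM. This estimate means a step of a 1.0-fold higher number from compound 3 to compound 4 (0.00 log units; within the scatter), expected to stay within the scatter.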

Compound 4, half-maximal inhibitory concentration: 4270 nM
Compound 4: middle estimate off by 1.3-fold (0.11 log units), on the high side; low and high end bracket the measured number.
By their numbers in this assay, from the lowest: compounds 4, 1, 3 and 2 (each within the scatter of the next).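

In this assay, the carbon next to the ring nitrogen takes a six-membered aromatic ring of carbon only as readily as a five-membered sulfur ring: the step of a 1.3-fold lower number from compound 3 to compound 4 (0.11 log units; within the scatter) stays within the scatter, and so does the step of a 1.5-fold lower number from compound 2 to compound 4 (0.18 log units; within the scatter) from the other thiophene isomer. For the compounds shown here, the result also adds the first comparison of where the chlorine sits on the chlorophenyl ring, and the step of a 1.3-fold lower number from compound 1 to compound 4 (0.11 log units; within the scatter) likewise shows no separation between the 4-chlorophenyl and 2-chlorophenyl groups, so across these compounds neither the ring type nor the chlorine position moves the number beyond the scatter. No measurement of any property of these groups is available to account for the result.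

From the compounds shown here alone, whether any group at this position can move the number beyond the scatter remains open, for example a saturated amine such as morpholine or a carboxylic acid in place of the phenyl. All four compounds also carry the 4-hydroxyphenyl group, so how a methoxy group or a bare phenyl would compare there is equally unknown.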